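The source may hold more compounds than are shown below. What is called first, only, known or untested is meant among the compounds shown, and "the series" means these compounds.

Measured in an ADME assay on microsomes from liver (Mus musculus) for metabolic stability, read by LC-MS, with a stated time of 10 min; on this read-out higher numbers stand for a more stable compound and lower numbers for a less stable compound:
Compound 1 `CCN(C[C@H]1Cc2c(cccc2N2CCNCC2)CN1)[C@H]1CCCc2cccnc21` gives 53.8%
Compound 2 `CCCN(C[C@H]1Cc2c(cccc2N2CCNCC2)CN1)[C@H]1CCCc2cccnc21` gives 87.4%

Going by the values given here, compound 2 holds the higher of these two numbers, and its only neighbour is compound 1, which lies well under it by a margin beyond the scatter. Compound 3 `c1cnc2c(c1)CCC[C@@H]2N(CC1CCCCC1)C[C@H]1Cc2c(cccc2N2CCNCC2)CN1` keeps the shared core and differs from compound 2 at one place (cyclohexyl in place of ethyl on a saturated chain carbon bound to an amine nitrogen). The same difference, cut one bond further out, reads propyl to cyclohexylmethyl.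

Among the compounds with values here, only one measured step bears on this change (a number 33.6 percentage points higher from compound 1 to compound 2 (beyond the scatter)). It is large and beyond the scatter, but it records only methyl in place of hydrogen on a saturated chain carbon. It involves no ring, so it gives no firm direction for cyclohexyl in place of ethyl. Compound 2, at 87.4% on a percentage read-out, also leaves little room for a further rise. A moderate fall with a wide margin is therefore expected, and the estimated step is (a number 12.4 percentage points lower from compound 2 to compound 3 (beyond the scatter)). In this assay compound 3 is expected at 75% (estimated range from 50% to 95%).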

Compound 3, percent of the compound remaining: 85.6%
Compound 3: the middle estimate sits 10.6 percentage points below what was measured, and the stated range covers the measured number.
By their numbers in this assay, from the lowest: compound 1; then compounds 3 and 2 (each within the scatter of the next).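

In this assay, the change at this place, on a saturated chain carbon bound to an amine nitrogen, now includes a ring: cyclohexyl in place of ethyl gives a number 1.8 percentage points lower from compound 2 to compound 3 (within the scatter), so the larger group, with its six-membered non-aromatic ring of carbon only, leaves the read-out within the scatter of the open propyl chain of compound 2. Set against the ethyl compound, the same place gives a number 31.8 percentage points higher from compound 1 to compound 3 (beyond the scatter), a large step like a number 33.6 percentage points higher from compound 1 to compound 2 (beyond the scatter), so the high reading at this position is no longer tied to an open chain and holds for both the propyl and the cyclohexylmethyl groups on the amine nitrogen. Nothing available says why these two different groups read alike or why both stand apart from compound 1.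

Still open, as far as these compounds go, is whether a smaller ring such as cyclopropyl, or a longer chain such as butyl, would stay with compound 2 and compound 3 or fall back towards compound 1. From the compounds shown here alone, it is equally open whether a ring carrying a heteroatom, such as tetrahydropyranyl, or a hydroxyl group on the chain would hold the reading at this place.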